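A few compounds are considered here, and "the series" means these few. Any claim that something is new, unique, unknown or untested is made for them only; others in the source may bear on it.

Measured compounds:
Compound 1 `COc1ccc(CNCCCNS(=O)(=O)c2cc(C(F)(F)F)cc(C(F)(F)F)c2)cc1OC`: 3600 nM
Compound 2 `O=S(=O)(NCCCNCc1cccc2ccccc12)c1cc(C(F)(F)F)cc(C(F)(F)F)c1`: 2700 nM

Both compounds share the bis(trifluoromethyl)phenyl sulfonamide and the three-carbon chain that carries the amine, and differ only in the aryl group on the saturated chain carbon bound to that amine nitrogen. In a functional assay on BE(2)-C cells (Homo sapiens) for inhibition, read by MTT assay, with a stated time of 72 h (on this read-out higher numbers stand for weaker inhibition of growth and lower numbers for stronger inhibition of growth), compound 1 gives 3600 nM, and compound 2 gives 2700 nM. Among the compounds with values here, on these two numbers compound 2 stands next to compound 1, the only step between them being a 1.3-fold lower number from compound 1 to compound 2 (0.12 log units; within the scatter).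

Compound 3 `O=S(=O)(NCCCNCc1cccc(Cl)c1)c1cc(C(F)(F)F)cc(C(F)(F)F)c1` continues this series at the same place: 3-chlorophenyl in place of naphthalen-1-yl on a saturated chain carbon bound to an amine nitrogen. Within the data shown here, the one measured step that bears on it, a 1.3-fold lower number from compound 1 to compound 2 (0.12 log units; within the scatter), shows that exchanging one aryl group for another at this position left the number within the scatter. Among the measured compounds shown here, no step to a monosubstituted phenyl is available, so the expectation rests on that single comparison. The estimated step is therefore a 1.3-fold higher number from compound 2 to compound 3 (0.11 log units; within the scatter), nothing beyond the scatter. Compound 3 is expected to give about 3500 nM in this assay, within a range from 1200 nM to 10000 nM.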

Compound 3, concentration for 50% growth inhibition: 6900 nM
Estimate against measurement, compound 3: 2.0-fold (0.29 log units) below, and the stated range covers the measured number.
By their numbers in this assay, from the lowest: compounds 2, 1 and 3 (each within the scatter of the next, the first and the last beyond it).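

In this assay, this position now shows its first step beyond the scatter: a 2.6-fold higher number from compound 2 to compound 3 (0.41 log units; beyond the scatter), as the two aromatic rings of naphthalen-1-yl give way to the single ring of 3-chlorophenyl. Not every exchange of aryl groups here separates the numbers, since a 1.9-fold higher number from compound 1 to compound 3 (0.28 log units; within the scatter), so only the two ends of the order of the three compounds lie apart. No measurement on hand accounts for this gap, and none tells whether the number of rings or the chlorine matters.

The compounds shown leave open how a plain phenyl or a naphthalen-2-yl group would read at this place, which could help separate the second ring from the chlorine. They also leave open whether a longer chain carrying the amine would shift these numbers.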